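Mirror-image configuration in a hydroxylated side chain

The compounds below may be only part of what the source reports. "The series", "measured", "known", "first", "only" and "open" are said of these compounds alone.

The measured compounds and their values:
compound 1 `O=C1c2c[n+]([O-])c3ccccc3c2C(=O)c2c1c1ccccc1n2Cc1cn(C[C@H](O)CO)nn1` — 1130 nM
compound 2 `CN1CCN(CCCCn2c3c(c4ccccc42)C(=O)c2c[n+]([O-])c4ccccc4c2C3=O)CC1` — 80 nM
compound 3 `CN(C)CCCCn1c2c(c3ccccc31)C(=O)c1c[n+]([O-])c3ccccc3c1C2=O` — 300 nM

In a toxicity assay on L02 cells (Homo sapiens) for cytotoxicity, read by MTT assay, with a stated time of 72 h (a lower number here means a stronger inhibitor, a higher number a weaker inhibitor), compound 1 stands highest of the three numbers. Its nearest neighbour is compound 3, reached by a 3.8-fold lower number from compound 1 to compound 3 (0.58 log units; beyond the scatter); its furthest is compound 2, reached by a 14-fold lower number from compound 1 to compound 2 (1.15 log units; beyond the scatter). Between those two, a 3.8-fold higher number from compound 2 to compound 3 (0.57 log units; beyond the scatter) separates the dimethylamino from the 4-methylpiperazin-1-yl chain end.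

Compound 4 `O=C1c2c[n+]([O-])c3ccccc3c2C(=O)c2c1c1ccccc1n2Cc1cn(C[C@@H](O)CO)nn1` is the next case. Compared with compound 1: the two compounds have the same atoms and bonds and differ only in configuration as drawn: 1 of 1 stereo elements differ; a stereocentre at a saturated chain carbon is drawn S in compound 1 and R in compound 4. The chain carrying the stereocentre is the same 1-(2,3-dihydroxypropyl)-1H-1,2,3-triazol-4-yl group that compound 1 bears on a saturated chain carbon bound to an aromatic nitrogen.

For the measured compounds named here, none of the measured steps bears directly on this change: each of them replaces the whole group at that position, and none alters a configuration alone. The measured compounds therefore give no guide to the size or direction of a purely configurational step, and the expectation for compound 4 is a step that stays within the scatter, in no set direction. Compound 4 is expected to give 1130 nM, with a range from 500 nM to 2500 nM, which means an estimated step of no change at the digits printed from compound 1 to compound 4 (within the scatter).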

Compound 4, half-maximal inhibitory concentration: 490 nM
Compound 4: the middle estimate sits 2.3-fold (0.36 log units) above what was measured, and the stated range ends above it.
By their numbers in this assay, from the lowest: compound 2; then compounds 3 and 4 (each within the scatter of the next); then compound 1.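

In this assay the change from S to R at the stereocentre gives a 2.3-fold lower number from compound 1 to compound 4 (0.36 log units; beyond the scatter) and so moves the number beyond the scatter, which none of the whole-group replacements could have shown; the step can be assigned to configuration alone because nothing else separates the pair: the fact that compounds 1 and 4 differ only in the configuration as drawn.

The configuration also alters how the triazole chain compares with the amine chains. Drawn R, the 1-(2,3-dihydroxypropyl)-1H-1,2,3-triazol-4-yl group gives a 1.6-fold higher number from compound 3 to compound 4 (0.21 log units; within the scatter) against the 3-(dimethylamino)propyl group, whereas the S form stood beyond the scatter from that group, and a 6.1-fold higher number from compound 2 to compound 4 (0.79 log units; beyond the scatter) still separates it from the 3-(4-methylpiperazin-1-yl)propyl group.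

The compounds shown leave open whether a configurational step of this kind would persist with an amine or a methoxy group in place of the secondary hydroxyl, or with a longer chain carrying the stereocentre. They also rest on a single pair of mirror-image side chains in this assay, so they cannot say whether the R form gives the lower number on any other side chain.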